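Replacing the methoxypropyl arm with a cyclopentyl ring

The source may hold more compounds than are shown below. What is called first, only, known or untested is meant among the compounds shown, and "the series" means these compounds.

Going by the values given here, compound 2 `CO[C@H](C)[C@H](N)CN(C(=O)[C@@H]1C[C@H]1c1ccccc1)c1ccc(-c2ccccc2)cc1` gives 0.68 nM in a functional assay for agonist activity at G protein-coupled receptor 88 (Homo sapiens), read by HTRF and cAMP accumulation (a higher number here means that more compound is needed for the effect, a lower number that less compound is needed), the lowest of the two numbers measured so far; compound 1 `CC[C@H](C)[C@@H](CN(C(=O)[C@@H]1C[C@H]1c1ccccc1)c1ccc(-c2ccccc2)cc1)NC(C)=O` gives 5.8 nM in this assay. Among the compounds with values here, the one measured step, an 8.5-fold lower number from compound 1 to compound 2 (0.93 log units; beyond the scatter), exchanged both the acetamido and the alkyl branch at once. Compound 3 `NC1(CN(C(=O)[C@@H]2C[C@H]2c2ccccc2)c2ccc(-c3ccccc3)cc2)CCCC1` differs from compound 2 by 1-aminocyclopentyl in place of 1-amino-2-methoxypropyl on a saturated chain carbon bound to an amide-type nitrogen. Within the data shown here, no measured step matches this change, so the expectation rests on compound 2 alone, with a modest move allowed in either direction: compound 3 is estimated at 2 nM, between 0.5 nM and 8 nM, an expected step of a 2.9-fold higher number from compound 2 to compound 3 (0.47 log units; beyond the scatter).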

Compound 3, half-maximal effective concentration: 0.57 nM
Beside the measured number, compound 3's estimate is 3.5-fold (0.55 log units) above it; the range from low to high includes it.
By their numbers in this assay, from the lowest: compounds 3 and 2 (each within the scatter of the next); then compound 1.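

Exchanging 1-amino-2-methoxypropyl for 1-aminocyclopentyl removes the oxygen and the defined stereocentres, yet the reading holds, with a 1.2-fold lower number from compound 2 to compound 3 (0.08 log units; within the scatter). The change from 1-acetamido-2-methylbutyl to 1-aminocyclopentyl gives a 10-fold lower number from compound 1 to compound 3 (1.01 log units; beyond the scatter), but it alters both the acetamido group and the carbon branch, so neither can be credited alone. No measurement here explains these results.

Still open, going by these compounds, is how a smaller cyclobutyl ring or a larger cyclohexyl ring would read at this place. On these data alone, a methylamino group in place of the amino group also remains open.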